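The source may hold more compounds than are shown below. What is called first, only, known or untested is meant among the compounds shown, and "the series" means these compounds.

Measured so far:
- compound 1 `C[C@H](c1ccc(-c2cc(F)ccc2-c2nc(=O)o[nH]2)cc1)N(CC1CC1)c1nc2c(C(=O)O)cccc2o1`: 2.3 nM
- compound 2 `CCCCN(c1nc2c(C(=O)O)cccc2o1)[C@H](C)c1ccc(-c2cc(Cl)ccc2-c2nc(=O)o[nH]2)cc1`: 1.2 nM

Of the compounds shown here, two have been tested in a functional assay on CAL1 cells for inhibition of chemerin-like receptor 1 (Homo sapiens), with a stated time of 45 min; a higher number here means a weaker inhibitor, a lower number a stronger inhibitor. Compound 1 gives 2.3 nM and compound 2 gives 1.2 nM. Compound 2 stands at one end of this short pair, but the gap to compound 1 is within the scatter of repeated measurements, so the two values cannot be told apart. The two also differ in more than one place, so nothing can be read from their pair about any single change.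

Compound 3 `CCCCN(c1nc2c(C(=O)O)cccc2o1)[C@H](C)c1ccc(-c2cc(F)ccc2-c2nc(=O)o[nH]2)cc1` has not yet been measured in this assay. It is built from compound 2 by a single change: fluoro in place of chloro on an aromatic carbon. Only one halogen is swapped for another at the same spot, and everything else in the molecule is kept.

Among the measured compounds shown here, no measured pair shows what this exact swap does. With the two known values lying so close together, the step from compound 2 to compound 3 is expected to be small, not clearly beyond the scatter in either direction, estimated as a 1.5-fold higher number from compound 2 to compound 3 (0.18 log units; within the scatter). Compound 3 is therefore expected to give about 1.8 nM, likely between 0.8 nM and 4 nM.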

Compound 3, half-maximal inhibitory concentration: 2.7 nM
Estimate against measurement, compound 3: 1.5-fold (0.18 log units) below; measured number inside the range.
By their numbers in this assay, from the lowest: compounds 2, 1 and 3 (each within the scatter of the next, the first and the last beyond it).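

In this assay, among the compounds shown here, the change to fluoro in place of chloro on this aromatic carbon gives a 2.3-fold higher number from compound 2 to compound 3 (0.35 log units; beyond the scatter) and so provides the first single-change comparison at this position, showing that the choice between these two halogens has a modest but measurable effect on the number. The other single-change comparison concerns a different part of the molecule, propyl in place of cyclopropyl on a saturated chain carbon bound to a nitrogen, and there a 1.2-fold higher number from compound 1 to compound 3 (0.07 log units; within the scatter) means that this exchange cannot be told apart from repeat-to-repeat variation when fluoro sits on the ring. Nothing in the available data explains why chloro and fluoro differ at this position.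

The compounds shown carry only these two halogens at this position, so it remains open how a hydrogen, a bromo, a methyl, a methoxy or a nitrile there would compare. For the compounds shown here, the chain exchange has also been seen only with fluoro on the ring, so whether it would likewise leave the number unresolved with chloro there is unknown.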